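Fluorine Added to the Benzyl Group of an Ethyl Ester

A few compounds are considered here, and "the series" means these few. Any claim that something is new, unique, unknown or untested is made for them only; others in the source may bear on it.

Of the compounds shown here, three with a shared core have been measured in an ADME assay on MT4 cells (Homo sapiens) for cytotoxicity, read by MTT assay; on this read-out higher numbers stand for lower toxicity in this test and lower numbers for higher toxicity in this test. Compound 3 `COc1cccc2c1c(C(=O)/C=C(\O)C(=O)O)cn2Cc1cccc(F)c1` gives 65800 nM, while compound 1 `COc1cccc2c1c(C(=O)/C=C(\O)C(=O)O)cn2Cc1cccc(F)c1F`, which differs from it by fluoro in place of hydrogen on an aromatic carbon, gives 17500 nM; this change produced a 3.8-fold lower number from compound 3 to compound 1 (0.58 log units; beyond the scatter). Compound 2 `CCOC(=O)/C(O)=C/C(=O)c1cn(Cc2cccc(F)c2)c2cccc(OC)c12` gives 63200 nM; it differs from compound 3 by ethyl in place of hydrogen on an oxygen next to a carbonyl group, and that change produced a 1.0-fold higher number from compound 2 to compound 3 (0.02 log units; within the scatter).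

Compound 4 `CCOC(=O)/C(O)=C/C(=O)c1cn(Cc2cccc(F)c2F)c2cccc(OC)c12` is not yet measured. It differs from compound 2 by fluoro in place of hydrogen on an aromatic carbon, which is the same change as that from compound 3 to compound 1: the place of the new fluoro is described in the same words in both pairs. The same change is expected to produce a step like a 3.8-fold lower number from compound 3 to compound 1 (0.58 log units; beyond the scatter), with a lower number after the change, because a 1.0-fold higher number from compound 2 to compound 3 (0.02 log units; within the scatter) lies within the scatter. The expected step is a 3.5-fold lower number from compound 2 to compound 4 (0.55 log units; beyond the scatter). Compound 4 is therefore estimated at 18000 nM, with a range from 7000 nM to 48000 nM.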

Compound 4, half-maximal cytotoxic concentration: 21100 nM
The estimate for compound 4 lay 1.2-fold (0.07 log units) below the measured number, within the range that was stated.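

In this assay, the fluoro that turns the 3-fluorobenzyl group into the 2,3-difluorobenzyl group gave a 3.0-fold lower number from compound 2 to compound 4 (0.48 log units; beyond the scatter), and this step agrees with the one seen earlier on the other core: the same change on two cores in this assay, a 3.8-fold lower number (0.58 log units; beyond the scatter) from compound 3 to compound 1 and a 3.0-fold lower number (0.48 log units; beyond the scatter) from compound 2 to compound 4, 1.3-fold (0.10 log units) apart, within the scatter of two such steps

Ethyl in place of hydrogen on the oxygen gave a 1.2-fold higher number from compound 1 to compound 4 (0.08 log units; within the scatter), so this second change also carried over between the two cores, again without a step beyond the scatter: the same change on two cores in this assay, a 1.0-fold higher number (0.02 log units; within the scatter) from compound 2 to compound 3 and a 1.2-fold lower number (0.08 log units; within the scatter) from compound 4 to compound 1, 1.3-fold (0.10 log units) apart, within the scatter of two such steps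

These two comparisons show that both changes carried across in this small set, but they rest on one read-out and four compounds, and they do not show why the number moves or whether the same would hold on any further core.

Going by these compounds, it remains open whether a chloro or methyl group in place of the new fluoro would give a similar step. On these data alone, it is equally open whether a longer chain in place of the ethyl would leave the number as unmoved as the ethyl does.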